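A few compounds are considered here, and "the series" means these few. Any claim that something is new, unique, unknown or untested is made for them only; others in the source may bear on it.

Compound 1 `COc1ccccc1C(=O)NC(CC(=O)O)c1ccc(C(C)(C)C)cc1`, compound 2 `CC(C)(C)c1ccc(C(CC(=O)O)NC(=O)c2c(Cl)cccc2Cl)cc1` and compound 3 `COc1ccccc1C(=O)NC(CC(=O)O)c1ccc(Cl)cc1Cl` share one core, and compound 4 `O=C(O)CC(NC(=O)c1c(Cl)cccc1Cl)c1ccc(Cl)cc1Cl` is the member not yet measured. In a functional assay on MDA-MB-436 cells (Homo sapiens) for antiproliferative activity, read by MTT assay, with a stated time of 24 h (a higher number here means a weaker inhibitor, a lower number a stronger inhibitor), compound 1 gives only the assay limit of > 100000 nM. In this assay compound 2 likewise returns only the limit of > 100000 nM. Compound 3 in this assay also stops at the limit of > 100000 nM. The change 2,6-dichlorophenyl in place of 2-methoxyphenyl on a carbonyl carbon yields a step that the two limits leave unreadable from compound 1 to compound 2, and the step cannot be read because every value sits at the limit of > 100000 nM in this assay, at which 3 of the 3 values shown sit. How the core of compound 3 differs from the core of compound 1 is not broken down here. The same change, (2,6-dichlorophenyl in place of 2-methoxyphenyl on a carbonyl carbon), carries compound 3 to compound 4. With no readable step to lean on, compound 4 is expected to give 100000 nM, between 30000 nM and 300000 nM. The estimated step of a number no higher from compound 3 to compound 4 (the limit leaves the size open) is expected to remain at the limit.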

Compound 4, half-maximal inhibitory concentration: > 100000 nM
Compound 4 gave a limit, no number (the forecaster's own chance of this, stated with the estimate: 85%); the middle value lies on the limit itself.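

No step can be read from compound 3 to compound 4, as both stop at an assay limit: the limit of > 100000 nM in this assay, at which 4 of the 4 values shown sit.

The compounds shown leave open what 2,6-dichlorophenyl in place of 2-methoxyphenyl does to potency in this assay.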